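A few compounds are considered here, and "the series" means these few. Any claim that something is new, unique, unknown or untested is made for them only; others in the source may bear on it.

Compound 1 `COc1ccc(C)cc1-c1c(C)nn(-c2nc(-c3ccc(Cl)c(Cl)c3)c(SC(C)C)s2)c1C(=O)O` and compound 2 `CC(=O)Nc1ccc(-c2c(C)nn(-c3nc(-c4ccc(Cl)c(Cl)c4)c(SC(C)C)s3)c2C(=O)O)cc1` share a core and differ only in the aryl group attached to it. In a functional assay on BJAB cells (Homo sapiens) for antiproliferative activity, with a stated time of 4 days (on this read-out higher numbers stand for an effect only at larger amounts of compound and lower numbers for an effect already at smaller amounts), compound 1 gives 9500 nM, and compound 2 gives 139000 nM. Going by the values given here, of these two numbers compound 1 holds the lower one, with compound 2 the only neighbour. Among the compounds with values here, the one measured step, a 15-fold higher number from compound 1 to compound 2 (1.17 log units; beyond the scatter), shows that replacing the 2-methoxy-5-methylphenyl group with 4-acetamidophenyl costs a great deal of activity in this assay.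

Compound 3 `Cc1cc(C#N)cc(-c2c(C)nn(-c3nc(-c4ccc(Cl)c(Cl)c4)c(SC(C)C)s3)c2C(=O)O)c1` has not yet been tested. It differs from compound 1 in the same place: 3-cyano-5-methylphenyl in place of 2-methoxy-5-methylphenyl on an aromatic carbon. The 3-cyano-5-methylphenyl group keeps the methyl but exchanges the methoxy for a nitrile and moves it to another position on the ring. Within the data shown here, the only step that bears on this change, a 15-fold higher number from compound 1 to compound 2 (1.17 log units; beyond the scatter), came from a different replacement, so it guides the direction more than the size. Since that step was a loss, compound 3 is expected to show a modest loss as well, roughly a 2.6-fold higher number from compound 1 to compound 3 (0.42 log units; beyond the scatter). The estimate for compound 3 in this assay is 25000 nM, within a range from 7000 nM to 90000 nM.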

Compound 3, half-maximal effective concentration: 4800 nM
Beside the measured number, compound 3's estimate is 5.2-fold (0.72 log units) above it, outside the stated range (below it).
By their numbers in this assay, from the lowest: compounds 3 and 1 (each within the scatter of the next); then compound 2.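

In this assay, the step of a 2.0-fold lower number from compound 1 to compound 3 (0.30 log units; within the scatter) means that 3-cyano-5-methylphenyl and 2-methoxy-5-methylphenyl cannot be told apart, so this position on the shared core accepts more than one substituted phenyl group without a measurable difference. The step of a 29-fold lower number from compound 2 to compound 3 (1.46 log units; beyond the scatter) then leaves compound 2, with its 4-acetamidophenyl group, apart from both other compounds, which shows that the earlier loss does not follow from simply giving up 2-methoxy-5-methylphenyl. No measurement at hand explains the gap between these aryl groups.

Going by these compounds, all three compounds carry a phenyl ring at this position, so it remains open whether a pyridine ring, or an amine or short alkyl chain in place of the ring, would fit the same picture. On these data alone, it is also open whether the large step goes with the acetamide itself or with where it sits on the ring, a question that a comparison with 3-acetamidophenyl or 4-aminophenyl could help to separate.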